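This account rests on a few compounds, and the source may have more. Where it says the series, first, only, none or still open, it means among the compounds named here.

Measured so far in a functional assay on CHO cells for agonist activity at Alpha-2C adrenergic receptor (Homo sapiens); on this read-out lower numbers stand for smaller maximal responses and higher numbers for larger maximal responses:
compound 1 `COc1ccc(S(C)(=O)=O)c(NCC2=NCCN2)c1` gives 49%
compound 2 `CC(C)S(=O)(=O)c1ccccc1NCC1=NCCN1` gives 50%
compound 3 `COc1ccc(SC)c(NCC2=NCCN2)c1` gives 74%

Compound 3 stands highest of the three, with compound 2 and compound 1 both below it beyond the scatter. For the measured compounds named here, the one single-change step in the set, a number 25 percentage points higher from compound 1 to compound 3 (beyond the scatter), concerns the methylsulfanyl group, which compound 4 keeps unchanged. Compound 4 `CSc1ccc(C(F)(F)F)cc1NCC1=NCCN1` differs from compound 3 by trifluoromethyl in place of methoxy on an aromatic carbon. Going by the values given here, no measured step alters the methoxy group, so this change has no direct precedent and its direction is open. The step of a number 9 percentage points lower from compound 3 to compound 4 (within the scatter) is therefore expected to be small, with a wide band. Compound 4 is estimated at 65%, within 45% to 85%.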

Compound 4, largest response reached (reported as maximum), in percent of the reference or control that the assay uses: 45%
Beside the measured number, compound 4's estimate is 20 percentage points above it; the measured number falls inside the stated range.
By their numbers in this assay, from the lowest: compounds 4, 1 and 2 (each within the scatter of the next); then compound 3.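

Trifluoromethyl in place of methoxy on this aromatic carbon, para to a methylsulfanyl group, gives a number 29 percentage points lower from compound 3 to compound 4 (beyond the scatter) in this assay, so the response depends on what this position carries. Keeping the methylsulfanyl group therefore does not by itself hold the response at the level of compound 3, 74% in this series. No supporting data on hand account for this drop.

On these data alone, whether a hydroxyl group or an amine at this position would retain the response of compound 3 stays open. Also open, as far as these compounds go, is how trifluoromethyl here would behave with methylsulfonyl in place of methylsulfanyl.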